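Compound 4: dipropylamino in place of (piperidin-1-yl)methyl

The compounds below may be only part of what the source reports. "The series", "measured", "known", "first", "only" and "open" are said of these compounds alone.

Compounds measured so far in a physicochemical assay for solubility, in phosphate buffer, measured as kinetic solubility, at pH 7.4 (a lower number here means a less soluble compound, a higher number a more soluble compound), are these
Compound 1 `Cc1ccc(C)c(-c2nc(CN3CCC(C(=O)NCCCN4C[C@H](C)C[C@H](C)C4)CC3)c(C)o2)c1` gives 56.1 ug/mL as a number
Compound 2 `Cc1oc(-c2ccccc2Cl)nc1CN1CCC(C(=O)NCCCN2C[C@H](C)C[C@H](C)C2)CC1` gives > 72 ug/mL as a limit
Compound 3 `Cc1ccccc1-c1nc(CN2CCC(C(=O)NCCCN3CCCCC3)CC2)c(C)o1` gives > 65 ug/mL as a limit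

Compound 3 thus has no number, only a limit in this assay and no exact position among the others. Compound 4 `CCCN(CCC)CCNC(=O)C1CCN(Cc2nc(-c3ccccc3C)oc2C)CC1` differs from compound 3 by one exchange: dipropylamino in place of (piperidin-1-yl)methyl on a saturated chain carbon, two bonds along the chain from an amide-type nitrogen. In words, dipropylamino stands in place of (piperidin-1-yl)methyl on a saturated chain carbon, two bonds along the chain from an amide-type nitrogen.

Among the compounds with values here, the only measured step, an at least 1.2-fold higher number from compound 1 to compound 2 (0.10 log units; that floor lies within the scatter), is a change on an aromatic carbon and does not touch this chain. Within the data shown here, no measured step covers the exchange itself. Among the measured compounds shown here, the one number available belongs to compound 1, at 56.1 ug/mL in the same assay, and it serves as a rough guide. No shift beyond the scatter is therefore expected, and the expected step is an at least 1.0-fold lower number from compound 3 to compound 4 (0.02 log units; that floor lies within the scatter) in this assay. Compound 4 is estimated at 62 ug/mL, with 35 ug/mL and 80 ug/mL as the ends of that estimate.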

Compound 4, solubility: > 65 ug/mL
Compound 4 ended at the assay's limit (the forecaster's own chance of this, stated with the estimate: 55%); middle value at least 1.0-fold (0.02 log units) away from the limit.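

In this assay compound 4 gives > 65 ug/mL, which is a limit and not a number. Within the data shown here, compound 3 also has only a limit, so no step between compound 3 and compound 4 can be read. The compounds shown leave open whether dipropylamino in place of (piperidin-1-yl)methyl shifts the read-out in this assay at all.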